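The source may hold more compounds than are shown below. What is called first, only, known or untested is meant among the compounds shown, and "the series" means these compounds.

Among the measured compounds shown here, compound 2, with the structure `COc1ccc(-c2ncnn2-c2cc(OC)c(OC)c(OC)c2)cc1`, is the only member of this small set to return a number in a functional assay on A549 cells (Homo sapiens) for antiproliferative activity, read by MTT assay, with a stated time of 72 h; on this read-out lower numbers stand for stronger inhibition and higher numbers for weaker inhibition: compound 2 gives 520 nM. Compound 1, with the structure `COc1cc(-n2ncnc2-c2ccc(OC(C)C)cc2)cc(OC)c1OC`, reaches only a limit of the assay in this assay, where compound 1 gives > 10000 nM. Compound 3, with the structure `COc1cc(-c2ncnn2-c2ccc([N+](=O)[O-])cc2)cc(OC)c1OC`, likewise sits at a limit in this assay, where compound 3 gives > 10000 nM. For the measured compounds named here, the one measured step, an at least 19-fold lower number from compound 1 to compound 2 (1.28 log units; beyond the scatter), concerns the oxygen-bound group on the trimethoxy-bearing ring and not the position that changes here. Compound 4, with the structure `COc1cc(-n2ncnc2-c2ccc(Cl)c(Cl)c2)cc(OC)c1OC`, differs from compound 2 as follows: 3,4-dichlorophenyl in place of 4-methoxyphenyl on an aromatic carbon. Going by the values given here, no measured step covers a change on this aromatic carbon, so the direction and size of the move are uncertain; the limit of compound 3, which carries a different group on this same aromatic carbon, is the nearest comparison and points toward weakening. Compound 4 is therefore expected to give 3000 nM, in the range 600 nM to 10000 nM, an estimated step of a 5.8-fold higher number from compound 2 to compound 4 (0.76 log units; beyond the scatter).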

Compound 4, half-maximal inhibitory concentration: > 10000 nM
Compound 4 was reported as a limit; the forecaster's own chance of this, stated with the estimate: 40%; middle value at least 3.3-fold (0.52 log units) away from the limit.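

Setting 3,4-dichlorophenyl in place of 4-methoxyphenyl on this aromatic carbon gives an at least 19-fold higher number from compound 2 to compound 4 (1.28 log units; beyond the scatter), the first listed step at this position, and it shows that this one change separates a measured number from a limit. In this assay compound 4 gives > 10000 nM, which is a limit of the assay and not a number. The step thus fixes a direction and a minimum size, but not the full size, and the limit recurs across this small set: the limit of > 10000 nM in this assay, at which 3 of the 4 values shown sit.

The compounds shown leave open whether the move follows from removing the methoxy group or from adding the two chlorine atoms. A 4-chlorophenyl, 4-hydroxyphenyl or 4-aminophenyl group on this aromatic carbon would bear on that question.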